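A few compounds are considered here, and "the series" means these few. Any claim that something is new, unique, unknown or untested is made for them only; others in the source may bear on it.

Working notes on the series. Compound 2 `CC(C)(C)c1ccc(N/N=C(\N=N\c2nnnn2-c2ccccc2)c2ccccc2)cc1` gives 3800 nM in an assay on lung for inhibition of Endothelin-converting enzyme 1 (Rattus norvegicus); on this read-out higher numbers stand for weaker inhibition and lower numbers for stronger inhibition; this is the larger of the two numbers recorded so far, yet it sits within the scatter of compound 1 `CCC(C)c1ccc(N/N=C(\N=N\c2nnnn2-c2ccccc2)c2ccccc2)cc1`, which gives 2700 nM in this assay. Going by the values given here, the one measured step, a 1.4-fold higher number from compound 1 to compound 2 (0.15 log units; within the scatter), exchanges one carbon-only substituent on the same aromatic carbon for another and stays within the scatter.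

Compound 3 `c1ccc(C(=N/Nc2ccc(C3CCCCC3)cc2)/N=N/c2nnnn2-c2ccccc2)cc1` carries the change (cyclohexyl in place of tert-butyl on an aromatic carbon). Among the compounds with values here, the step from compound 1 to compound 2 bears on it insofar as it too replaces a carbon-only substituent at this position, and that step was small; no measured step matches the entry of a six-membered non-aromatic ring, so nothing here points to a change beyond the scatter in either direction. For compound 3 the expected step is therefore a 1.3-fold lower number from compound 2 to compound 3 (0.10 log units; within the scatter). Compound 3 is estimated at 3000 nM in this assay, with a range from 1000 nM to 9000 nM.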

Compound 3, half-maximal inhibitory concentration: 3600 nM
For compound 3 the middle estimate is 1.2-fold (0.08 log units) below the measured one, and the stated range covers the measured number.
By their numbers in this assay, from the lowest: compounds 1, 3 and 2 (each within the scatter of the next).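

In this assay, cyclohexyl in place of tert-butyl on the aromatic carbon gives a 1.1-fold lower number from compound 2 to compound 3 (0.02 log units; within the scatter), and cyclohexyl in place of sec-butyl gives a 1.3-fold higher number from compound 1 to compound 3 (0.12 log units; within the scatter). A six-membered non-aromatic ring of carbon only at this position therefore stands within the scatter of both open branched groups, so compound 1, compound 2 and compound 3 cannot be separated on this read-out. No supporting measurement is available to explain this closeness.

As far as these compounds go, all three substituents here contain carbon only, so it remains open whether an amine, a carboxylic acid or a methoxy group at this position would move the number beyond the scatter. Also open, from the compounds shown here alone, is whether a longer chain, or a change elsewhere on the shared core, would do so.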